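Swapping a thiophene for a pyridine on a weakly cytotoxic scaffold

A few compounds are considered here, and "the series" means these few. Any claim that something is new, unique, unknown or untested is made for them only; others in the source may bear on it.

Of the compounds shown here, three share the same core and have been tested in a functional assay on HCT-15 cells (Homo sapiens) for cytotoxicity, read by CCK-8 assay and cell counting, with a stated time of 2 days; on this read-out lower numbers stand for stronger inhibition and higher numbers for weaker inhibition. Compound 1 `Oc1ccc(-c2cc(-c3cccc(Cl)c3)nc(-c3ccccn3)c2)cc1` gives 28200 nM in this assay. Compound 2 `Oc1cccc(-c2cc(-c3ccc(Cl)cc3)nc(-c3cccs3)c2)c1` gives 9280 nM in this assay, the lower of the two numbers; compound 1 sits a good deal higher, and that gap is beyond the usual scatter. Compound 3 `Oc1cccc(-c2cc(-c3ccncc3)nc(-c3ccccc3Cl)c2)c1` gives "not determined" (no result reported) in this assay; no result was reported for it, so it adds nothing to the numbers.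

Compound 4 `Oc1cccc(-c2cc(-c3ccc(Cl)cc3)nc(-c3ccccn3)c2)c1` is the next member. It differs from compound 2 in one spot: pyridin-2-yl in place of thiophen-2-yl on an aromatic carbon. For the measured compounds named here, no pair of measured compounds differs by exactly this change, so there is no measured step to lean on. Compound 1 does carry the pyridin-2-yl group, but on a core that differs in two other places. Its value cannot be read as a guide.

The expectation for compound 4 is therefore a modest shift, most likely toward a somewhat higher number than compound 2, but not clearly beyond the scatter, giving an expected step of a 1.4-fold higher number from compound 2 to compound 4 (0.15 log units; within the scatter). For compound 4 the estimate in this assay is 13000 nM, with a likely range from 4500 nM to 40000 nM.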

Compound 4, half-maximal inhibitory concentration: 13500 nM
The estimate for compound 4 lay 1.0-fold (0.02 log units) below the measured number; the range from low to high includes it.
By their numbers in this assay, from the lowest: compounds 2 and 4 (each within the scatter of the next); then compound 1.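

In this assay, for the compounds shown here, the change at this position can now be read directly for the first time, and it gives a 1.5-fold higher number from compound 2 to compound 4 (0.16 log units; within the scatter) on an otherwise identical structure. Within the usual scatter, compound 2 and compound 4 cannot be told apart, so this position takes either the five-membered thiophen-2-yl ring or the six-membered pyridin-2-yl ring without a difference that this read-out can resolve, even though nitrogen replaces sulfur and the group gains a heavy atom. Both groups count one hydrogen-bond acceptor and no donors, but no measurement presented here accounts for why the two compounds read alike.

The compounds shown leave open whether this position would respond differently to a group that is not an aromatic ring, such as an amine, a carboxylic acid or a longer alkyl chain. They also leave open whether the same swap would again give so small a step if the 3-hydroxyphenyl or 4-chlorophenyl group on the shared core were replaced.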